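The compounds below may be only part of what the source reports. "The series", "measured", "known", "first", "only" and "open" are said of these compounds alone.

Within the data shown here, compound 2 `COc1ccc(/C=C/c2cc(OC)cc(OC)c2/C=C/C(=O)c2cc3cc(F)ccc3oc2=O)cc1` holds the only actual number in an assay on isolated protein for inhibition of Amine oxidase [flavin-containing] B (Homo sapiens), read by fluorescence, with a stated time of 15 min (on this read-out higher numbers stand for weaker inhibition and lower numbers for stronger inhibition), where compound 2 gives 10200 nM. Compound 1 `COc1ccc(/C=C/c2cc(OC)cc(OC)c2/C=C/C(=O)c2cc3cc(OC)ccc3oc2=O)cc1` reaches only a limit in this assay, recorded as > 60000 nM. The step of an at least 5.8-fold lower number from compound 1 to compound 2 (0.76 log units; beyond the scatter) therefore rests on the limit of > 60000 nM in this assay, at which 1 of the 2 values shown sits, at one end and cannot be sized more closely than that. Compound 3 `COc1ccc(/C=C/c2cc(OC)cc(OC)c2/C=C/C(=O)c2cc3cc(C)ccc3oc2=O)cc1` differs from compound 2 by methyl in place of fluoro on an aromatic carbon. No measured step exchanges fluoro for methyl at this carbon; the one step shown, methoxy to fluoro, is the only guide and touches neither the group that enters nor a close relative of it. In this assay compound 3 is therefore expected to land near compound 2, with wide uncertainty, estimated at 15000 nM with a range from 5000 nM to 60000 nM. The expected step of a 1.5-fold higher number from compound 2 to compound 3 (0.17 log units; within the scatter) stays within the usual scatter.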

Compound 3, half-maximal inhibitory concentration: 5090 nM
Estimate against measurement, compound 3: 2.9-fold (0.47 log units) above, within the range that was stated.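

At this carbon of the shared core, this assay now gives two actual numbers, and a 2.0-fold lower number from compound 2 to compound 3 (0.30 log units; within the scatter) does not separate methyl from fluoro. The earlier gain on leaving methoxy is therefore not peculiar to fluoro, as methyl shows it too, with an at least 11-fold lower number from compound 1 to compound 3 (1.07 log units; beyond the scatter). The size of that step stays open on one side, as the value of compound 1 is a limit: the limit of > 60000 nM in this assay, at which 1 of the 3 values shown sits.

On these data alone, whether chloro, a nitrile or an amine at this carbon would separate from methyl and fluoro remains open, as does whether a carboxylic acid would fall with methoxy. As far as these compounds go, all three compounds share the rest of the structure, so it also remains open whether the same exchanges would read alike with the methoxy groups elsewhere on the core changed.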